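Replacing oxetan-3-yl with ethylcarbamoyl: a clearance estimate

The source may hold more compounds than are shown below. What is called first, only, known or untested is meant among the compounds shown, and "the series" means these compounds.

Measured in an in vitro ADME assay on microsomes from liver (Mus musculus) for pharmacokinetics, read by LC-MS, with a stated time of 10 min, tested at 1 uM; a higher number here means faster removal of the compound, a lower number slower removal:
Compound 1 `CN1C[C@H](C(=O)Nc2ccccc2)[C@@H](c2ccc(/C=C/C(=O)Nc3ccccc3N)cc2)C1`: 67 mL/min/kg
Compound 2 `Nc1ccccc1NC(=O)/C=C/c1ccc([C@H]2CN(C3COC3)C[C@@H]2C(=O)Nc2ccc(Cl)cc2)cc1`: 42 mL/min/kg

In this assay, compound 2 stands at 42 mL/min/kg, which lies within the scatter of compound 1 at 67 mL/min/kg. Compound 3 `CCNC(=O)N1C[C@H](C(=O)Nc2ccc(Cl)cc2)[C@@H](c2ccc(/C=C/C(=O)Nc3ccccc3N)cc2)C1` carries ethylcarbamoyl in place of oxetan-3-yl on an amine nitrogen in a ring. For the measured compounds named here, no measured pair shows this change, so no step beyond the scatter is expected in this assay, and no firm direction is expected either. The expected step of a 1.1-fold higher number from compound 2 to compound 3 (0.03 log units; within the scatter) is therefore small. For compound 3 the estimated clearance is 45 mL/min/kg (expected range 22 mL/min/kg to 85 mL/min/kg).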

Compound 3, clearance: 25 mL/min/kg
Estimate against measurement, compound 3: 1.8-fold (0.26 log units) above, and the stated range covers the measured number.
By their numbers in this assay, from the lowest: compounds 3, 2 and 1 (each within the scatter of the next, the first and the last beyond it).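

On the amine nitrogen in a ring of the shared core, ethylcarbamoyl in place of oxetan-3-yl gives a 1.7-fold lower number from compound 2 to compound 3 (0.23 log units; within the scatter) in this assay. At this position, then, an open group with a hydrogen-bond donor and a double bond outside aromatic rings takes the place of a four-membered ring without a step beyond the scatter. No measurement here bears on the reason for this result. On these data alone, whether a longer chain such as butylcarbamoyl or a bare amine hydrogen on this nitrogen would move the clearance beyond the scatter stays open.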